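The compounds below may be only part of what the source reports. "The series", "measured", "known", "first", "only" and "open" are said of these compounds alone.

Measured compounds:
- compound 1, `COc1cccc(COc2ccc3cc(C(=O)/C=C/c4cc(OC)ccc4OC)c(=O)oc3c2)c1`: 13800 nM
- compound 2, `COc1cccc(/C=C/C(=O)c2cc3ccc(O)cc3oc2=O)c1OC`: 7000 nM

Both compounds were read in a functional assay on MOLT-4 cells (Homo sapiens) for cytotoxicity, read by MTT assay, with a stated time of 72 h; a higher number here means a weaker inhibitor, a lower number a stronger inhibitor. Compound 1 gives 13800 nM and compound 2 gives 7000 nM; these two numbers lie within the usual scatter of each other, so compound 1 cannot be separated from compound 2 on this assay, and no ranking between them is supported. Nothing further is known about either.

The unmeasured compound 3, `COc1cccc(COc2ccc3cc(C(=O)/C=C/c4c(Cl)cccc4Cl)c(=O)oc3c2)c1`, keeps the core of compound 1 and differs in one place: 2,6-dichlorophenyl in place of 2,5-dimethoxyphenyl on a double-bonded chain carbon bound to a double-bonded chain carbon. Among the measured compounds shown here, no step between two measured compounds covers this kind of change, so the direction cannot be read from the series. For the measured compounds named here, with only a single pair in hand, and that pair within scatter, the expectation is a step of modest size, if any, likely a somewhat lower number, but not one that can be called beyond the scatter with confidence.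

On that basis compound 3 is expected to give about 8000 nM in this assay, with a range from 2500 nM to 25000 nM. The step this estimate means, a 1.7-fold lower number from compound 1 to compound 3 (0.24 log units; within the scatter), is an expectation only.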

Compound 3, half-maximal inhibitory concentration: 12500 nM
Estimate against measurement, compound 3: 1.6-fold (0.19 log units) below, and the stated range covers the measured number.
By their numbers in this assay, from the lowest: compounds 2, 3 and 1 (each within the scatter of the next).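

In this assay, 2,6-dichlorophenyl in place of 2,5-dimethoxyphenyl on a double-bonded chain carbon bound to a double-bonded chain carbon gives a 1.1-fold lower number from compound 1 to compound 3 (0.04 log units; within the scatter), the first single-place step available in this series. This position therefore accepts an exchange of one substituted phenyl for another, including the loss of the hydrogen-bond acceptors counted on 2,5-dimethoxyphenyl, without a number that can be separated from that of compound 1, although this single step says nothing about other groups at the same place. Nothing available here bears on why the two groups cannot be told apart in this assay.

From the compounds shown here alone, whether any group at this place can move the number beyond the scatter stays open, and a phenyl carrying a dimethylamino group or a carboxylic acid, or a longer saturated alkyl chain in place of the phenyl, would test that. Among the compounds shown here, what the rest of the molecule contributes also stays open, since compound 2 differs from compound 1 and from compound 3 in more than one place and gives no clean step.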